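A few compounds are considered here, and "the series" means these few. Any claim that something is new, unique, unknown or untested is made for them only; others in the source may bear on it.

Of the compounds shown here, three sharing one core have been tested in a functional assay on MCF7 cells (Homo sapiens) for inhibition, read by MTT assay, with stated times of 18 h and 4 h; a lower number here means a stronger inhibitor, a higher number a weaker inhibitor. Compound 2 `CCCCCCCCCCOP(=O)(O)OCCSC(=S)N1CCCCC1` gives 7240 nM in this assay. Compound 1 `CCCCCCCCCCOP(=O)(O)OCCSC(=S)N1CCCC1` differs from compound 2 by pyrrolidin-1-yl in place of piperidin-1-yl on a thiocarbonyl carbon; in this assay compound 1 gives 70000 nM, a step of a 9.7-fold higher number from compound 2 to compound 1 (0.99 log units; beyond the scatter). Compound 3 `CCCCCCCCCCCCCCCCOP(=O)(O)OCCSC(=S)N1CCCCC1` differs from compound 2 by hexyl in place of hydrogen on a saturated chain carbon, ten or more bonds along the chain from an oxygen on an unsaturated carbon, and in this assay compound 3 gives 29000 nM, a step of a 4.0-fold higher number from compound 2 to compound 3 (0.60 log units; beyond the scatter). Compound 4 `CCCCCCCCCCCCCCCCOP(=O)(O)OCCSC(=S)N1CCCC1` has not yet been measured; it keeps the core of compound 3 and differs from it by pyrrolidin-1-yl in place of piperidin-1-yl on a thiocarbonyl carbon, the same change that led from compound 2 to compound 1. A weakening of similar size is expected for compound 4 because a 9.7-fold higher number from compound 2 to compound 1 (0.99 log units; beyond the scatter) was modest yet beyond the scatter. For compound 4 the expected step is a 6.9-fold higher number from compound 3 to compound 4 (0.84 log units; beyond the scatter). Compound 4 is estimated to give about 200000 nM, likely between 60000 nM and 600000 nM.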

Compound 4, half-maximal inhibitory concentration: 72000 nM
Compound 4: the middle estimate sits 2.8-fold (0.44 log units) above what was measured; low and high end bracket the measured number.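

In this assay, pyrrolidin-1-yl in place of piperidin-1-yl on a thiocarbonyl carbon again gives a 2.5-fold higher number from compound 3 to compound 4 (0.39 log units; beyond the scatter), so the direction of the change carries over to the second core, but its size does not: the same change on two cores in this assay, a 9.7-fold higher number (0.99 log units; beyond the scatter) from compound 2 to compound 1 and a 2.5-fold higher number (0.39 log units; beyond the scatter) from compound 3 to compound 4, 3.9-fold (0.59 log units) apart, beyond the scatter of two such steps With pyrrolidin-1-yl present, hexyl in place of hydrogen on the chain gives only a 1.0-fold higher number from compound 1 to compound 4 (0.01 log units; within the scatter), so that change also depends on its partner: the same change on two cores in this assay, a 4.0-fold higher number (0.60 log units; beyond the scatter) from compound 2 to compound 3 and a 1.0-fold higher number (0.01 log units; within the scatter) from compound 1 to compound 4, 3.9-fold (0.59 log units) apart, beyond the scatter of two such steps These two pairs, from one assay, show that the two changes do not add up independently, but they do not show why or whether this holds for other compounds.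

As far as these compounds go, how a morpholin-4-yl or azepan-1-yl group would behave at this place remains open. So does the effect of a shorter or longer chain.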